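The source may hold more compounds than are shown below. What is called first, only, known or untested is meant among the compounds shown, and "the series" means these compounds.

Measured compounds in the series:

compound 1: `Cn1cncc1C(OCc1ccc(C#N)cc1C#Cc1ccccn1)c1ccc(C#N)cc1` — > 0.1 nM
compound 2: `Cn1cncc1C(OCc1ccc(C#N)cc1C#Cc1ccc(C#N)cc1)c1ccc(C#N)cc1` — 11.6 nM
compound 3: `Cn1cncc1C(OCc1ccc(C#N)cc1C#Cc1ccc(-c2ccccc2)cc1)c1ccc(C#N)cc1` — > 0.1 nM

For the measured compounds named here, in a functional assay on NIH3T3 cells (Mus musculus) (a higher number here means that more compound is needed for the effect, a lower number that less compound is needed), compound 2 gives 11.6 nM, the only number among the three values. For compound 1 the value of > 0.1 nM is a limit of the assay, not a number. For compound 3 the value of > 0.1 nM is likewise a limit. The two limits sit at the limit of > 0.1 nM in this assay, at which 2 of the 3 values shown sit. The step that the limit leaves unreadable from compound 1 to compound 2 is therefore unreadable in size, as are a step that the two limits leave unreadable from compound 1 to compound 3 and a step that the limit leaves unreadable from compound 2 to compound 3.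

Compound 4 is `Cn1cncc1C(OCc1ccc(C#N)cc1C#CC(C)(C)C)c1ccc(C#N)cc1`; it is yet to be measured in this assay. It differs from compound 2 as follows: tert-butyl in place of 4-cyanophenyl on a triple-bonded carbon

Going by the values given here, none of the measured steps touches a tert-butyl, and none gives a readable size. Among the compounds with values here, the only firm anchor is compound 2 itself. The expectation for compound 4 rests on that anchor alone and is wide: the step of a 2.6-fold higher number from compound 2 to compound 4 (0.41 log units; beyond the scatter) is estimated, in either direction, with no secure reading. For compound 4 the estimate is 30 nM, within 3 nM to 300 nM.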

Compound 4, half-maximal effective concentration: 76.9 nM
Estimate against measurement, compound 4: 2.6-fold (0.41 log units) below; low and high end bracket the measured number.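

In this assay, for the compounds shown here, tert-butyl in place of 4-cyanophenyl gives a 6.6-fold higher number from compound 2 to compound 4 (0.82 log units; beyond the scatter), the first step of readable size on this triple-bonded carbon. A measurable value therefore does not depend on an aromatic ring or a nitrile at this place, although the change to the smaller, ring-free group carries a modest cost. The steps to compound 4 from compound 1 and from compound 3 cannot be read, and the values of compound 1 and compound 3 are limits, not numbers: the limit of > 0.1 nM in this assay, at which 2 of the 4 values shown sit.

Going by these compounds, the step changes ring, nitrile and heavy-atom count together, so the share of each in the higher number remains open; a plain phenyl at this place would separate the nitrile from the ring. Also open, on these data alone, is how an aminomethyl group, a carboxylic acid or a longer alkyl chain would read on the same triple-bonded carbon.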